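The source may hold more compounds than are shown below. What is called first, only, known or untested is meant among the compounds shown, and "the series" means these compounds.

Measured compounds:
compound 1 `C=CCn1c(=O)/c(=C\c2cccc(Cl)c2)[nH]c(=O)/c1=C\c1ccccc1OC` — 5200 nM
compound 2 `C=CCn1c(=O)/c(=C\c2ccc(Cl)c(Cl)c2)[nH]c(=O)/c1=C\c1ccccc1OC` — "not active" (no number reported)
compound 3 `C=CCn1c(=O)/c(=C\c2ccc(F)c(Br)c2)[nH]c(=O)/c1=C\c1ccccc1OC` — "not active" (no number reported)

All three share one core and were tested in a functional assay on A549 cells (Homo sapiens) for cytotoxicity, read by CCK-8 assay, with a stated time of 72 h; a higher number here means a weaker inhibitor, a lower number a stronger inhibitor. Among the measured compounds shown here, compound 1 is the only one with a number, giving 5200 nM. Compound 2 was reported only as "not active" (no number reported). Compound 3 likewise stands without a single number, reported as "not active" (no number reported); it is one of two entries in this set for which no value was recorded, so its place among the measured compounds cannot be fixed more closely than that.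

The next compound, compound 4 `C=CCn1c(=O)/c(=C\c2cc(F)ccc2C)[nH]c(=O)/c1=C\c1ccccc1OC`, keeps the core and the allyl and methoxyphenyl parts of compound 3 and changes the other aryl group: 5-fluoro-2-methylphenyl in place of 3-bromo-4-fluorophenyl on a double-bonded chain carbon bound to an aromatic carbon. For the measured compounds named here, no step between two measured compounds with a number is available to calibrate this change, and the one compound with a number, compound 1, differs from compound 3 and compound 4 at the same aryl group. Nothing in the set therefore points to a move beyond the scatter in either direction; the most that can be said is that the measured compounds cluster at weak or unreported activity.

For compound 4 in this assay the expected half-maximal inhibitory concentration is 9000 nM, with a range of 3000 nM to 40000 nM, and a real chance that only "not active" is reported again.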

Compound 4, half-maximal inhibitory concentration: 4900 nM
For compound 4 the middle estimate is 1.8-fold (0.26 log units) above the measured one; measured number inside the range.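

The aryl group on a double-bonded chain carbon bound to an aromatic carbon now has its first readable step: in this assay, 5-fluoro-2-methylphenyl in place of 3-chlorophenyl gives a 1.1-fold lower number from compound 1 to compound 4 (0.03 log units; within the scatter), so these two groups cannot be told apart in this read-out. The result also shows that a number at this position does not belong to compound 1 alone: compound 2 and compound 3 were reported only as "not active", whereas compound 4 gives 4900 nM. No supporting measurement is available to explain either observation.

With a single step, the compounds shown leave open whether the methyl or the fluorine of 5-fluoro-2-methylphenyl matters on its own, and how an amine or a nitrile on that aryl ring would read in this assay. They also leave open what would follow if the allyl group gave way to a longer chain or a carboxylic acid were placed on the methoxyphenyl group, since both parts stay the same throughout.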